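Replacing amino with methoxy in compound 3

The compounds below may be only part of what the source reports. "The series", "measured", "known", "first", "only" and "open" are said of these compounds alone.

Of the compounds shown here, three sharing one core have been measured in a functional assay on A549 cells (Homo sapiens) for antiproliferative activity, read by MTT assay, with a stated time of 72 h (on this read-out higher numbers stand for weaker inhibition and lower numbers for stronger inhibition), so far. There compound 1 (`COc1cc(-n2cnc3ccc(-c4ccc(C(C)=O)cc4)cc32)cc(OC)c1OC`) gives 2510 nM and compound 2 (`COc1cc(-n2cnc3ccc(-c4ccc([N+](=O)[O-])cc4)cc32)cc(OC)c1OC`) gives 8940 nM while compound 3 (`COc1cc(-n2cnc3ccc(-c4cccc(N)c4)cc32)cc(OC)c1OC`) gives 640 nM as the lowest number, which makes it the strongest of the three.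

Compound 4 (`COc1cccc(-c2ccc3ncn(-c4cc(OC)c(OC)c(OC)c4)c3c2)c1`) has methoxy in place of amino on an aromatic carbon meta to a large group. Within the data shown here, no measured pair makes this exact swap, so the evidence is indirect. Changing the substituted phenyl group gave a 3.9-fold lower number from compound 1 to compound 3 (0.59 log units; beyond the scatter) and also a 14-fold lower number from compound 2 to compound 3 (1.15 log units; beyond the scatter) as modest and large steps. Swapping acetyl for nitro gave a 3.6-fold higher number from compound 1 to compound 2 (0.55 log units; beyond the scatter) as another modest step. Compound 3 alone carries amino, and these three compounds cannot separate the effect of that group from the effect of its place.

A modest upward step in this assay is therefore expected, estimated as a 2.3-fold higher number from compound 3 to compound 4 (0.37 log units; beyond the scatter) for this swap. The estimate for compound 4 is 1500 nM with an expected range of 450 nM to 4500 nM when measured.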

Compound 4, half-maximal inhibitory concentration: 3180 nM
Compound 4: the middle estimate sits 2.1-fold (0.33 log units) below what was measured, and the stated range covers the measured number.
By their numbers in this assay, from the lowest: compound 3; then compounds 1 and 4 (each within the scatter of the next); then compound 2.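

In this assay, methoxy in place of amino at this same place gives a 5.0-fold higher number from compound 3 to compound 4 (0.70 log units; beyond the scatter) and thus separates the group from its place: with the place held fixed, the group alone changes the number beyond the scatter. The 3-methoxyphenyl group therefore does not carry the low number of the 3-aminophenyl group, so having a substituent at this place is not enough to reach it. Against the other two compounds, the change gives a 2.8-fold lower number from compound 2 to compound 4 (0.45 log units; beyond the scatter) and a 1.3-fold higher number from compound 1 to compound 4 (0.10 log units; within the scatter), which puts the 3-methoxyphenyl and 4-acetylphenyl groups level in this assay.

As far as these compounds go, whether another group at this place, such as hydroxyl or dimethylamino, would match amino remains open, as does how amino would fare where compound 1 and compound 2 carry acetyl and nitro. Nothing shown here gives a measured reason for the gap between amino and methoxy.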